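The compounds below may be only part of what the source reports. "The series", "measured", "known", "first", "only" and "open" are said of these compounds alone.

Values measured in an ADME assay on NL20 cells (Homo sapiens) for antiproliferative activity, read by MTT assay, with a stated time of 24 h; a higher number here means a weaker inhibitor, a lower number a stronger inhibitor:

Compound 1 `COc1cc(/C=C/C(=O)NNC(=O)c2ccccc2)ccc1O` gives 9550 nM
Compound 2 `COc1ccc(C(=O)NNC(=O)/C=C/c2ccc(O)c(OC)c2)cc1` gives > 10000 nM (a limit of the assay)
Compound 3 `COc1cc(/C=C/C(=O)NNC(=O)c2ccccc2)cc(OC)c1O` gives > 10000 nM (a limit of the assay)

Compound 3 stands at > 10000 nM as a limit of the assay and not as a number. The series is marked by the limit of > 10000 nM in this assay, at which 2 of the 3 values shown sit, and only compound 1 has a true number.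

Compound 4 `COc1ccc(C(=O)NNC(=O)/C=C/c2cc(OC)c(O)c(OC)c2)cc1` comes from compound 3 through (methoxy in place of hydrogen on an aromatic carbon), which is methoxy in place of hydrogen on an aromatic carbon, or phenyl to 4-methoxyphenyl. Among the compounds with values here, the closest precedent is an at least 1.0-fold higher number from compound 1 to compound 2 (0.01 log units; that floor lies within the scatter), since that step makes the same phenyl to 4-methoxyphenyl change. A second precedent is an at least 1.0-fold higher number from compound 1 to compound 3 (0.01 log units; that floor lies within the scatter), where methoxy replaces hydrogen at another place. As far as these compounds go, both are floors rather than measured sizes, so the true size of each stays open. Neither shows a lower number in this assay, and no step beyond the scatter can be forecast from them. Any movement is expected to be towards a higher number, meaning a weaker inhibitor. The expected step is a step that the limit leaves unreadable from compound 3 to compound 4 and it rests on a limit at its start. Compound 4 is estimated at 13000 nM, with an expected range of 7000 nM to 25000 nM and a good chance of being reported only as a limit.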

Compound 4, half-maximal inhibitory concentration: 9420 nM
Compound 4: middle estimate off by 1.4-fold (0.14 log units), on the high side, within the range that was stated.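

In this assay, within the data shown here, the phenyl to 4-methoxyphenyl change on the core of compound 3 gives an at least 1.0-fold lower number from compound 3 to compound 4 (0.02 log units; that floor lies within the scatter), so this change now ends on a true number, whereas the earlier steps each ended on a limit of the assay. Methoxy at the other place reads alike, with an at least 1.0-fold lower number from compound 2 to compound 4 (0.02 log units; that floor lies within the scatter), and this step also cannot be told apart from its earlier counterpart: the same change on two cores in this assay, an at least 1.0-fold higher number (0.01 log units; that floor lies within the scatter) from compound 1 to compound 3 and an at least 1.0-fold lower number (0.02 log units; that floor lies within the scatter) from compound 2 to compound 4; the limit leaves it open whether they differ The phenyl to 4-methoxyphenyl change shows the same openness, so the compounds give no sign that methoxy para to a large group truly strengthens or weakens inhibition: the same change on two cores in this assay, an at least 1.0-fold higher number (0.01 log units; that floor lies within the scatter) from compound 1 to compound 2 and an at least 1.0-fold lower number (0.02 log units; that floor lies within the scatter) from compound 3 to compound 4; the limit leaves it open whether they differ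

The true size of all these steps cannot be read, and the series remains largely bounded by a single assay limit: the limit of > 10000 nM in this assay, at which 2 of the 4 values shown sit. The compounds shown also leave open whether an amine, a carboxylic acid or a longer chain such as ethoxy in place of the methoxy on this aromatic ring would bring a step beyond the scatter.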